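Branching the amine chain: isopropyl in place of propyl

This account rests on a few compounds, and the source may have more. Where it says the series, first, only, none or still open, it means among the compounds named here.

Compound 1 `CCCN(C)/N=N/c1ccc(C(=O)O)cc1` gives 0.46 in a physicochemical assay for lipophilicity; a lower number here means a more polar compound, a higher number a more lipophilic compound.
Compound 2 `CCCCCN(C)/N=N/c1ccc(C(=O)O)cc1` gives 1.49 in this assay.
Compound 3 `CCCCCCCN(C)/N=N/c1ccc(C(=O)O)cc1` gives 2.58 in this assay.

Compound 1 stands lowest of the three in this assay; its nearest neighbour is compound 2, and compound 3 lies furthest away. The measured steps all lengthen the chain: a number 1.03 log units higher from compound 1 to compound 2 (beyond the scatter), a number 1.09 log units higher from compound 2 to compound 3 (beyond the scatter) and a number 2.12 log units higher from compound 1 to compound 3 (beyond the scatter). Compound 4 `CC(C)N(C)/N=N/c1ccc(C(=O)O)cc1` carries the same atoms as compound 1, joined differently: isopropyl in place of propyl on an amine nitrogen. Within the data shown here, no measured step changes branching without changing the count of chain carbons, so none bears directly on this change; a step in this assay no larger than the scatter is expected, if anything slightly downward, a number 0.16 log units lower from compound 1 to compound 4 (within the scatter). Compound 4 is therefore estimated at 0.3, within 0 to 0.6.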

Compound 4, partition coefficient: 0.34
The estimate for compound 4 lay 0.04 log units below the measured number; low and high end bracket the measured number.
By their numbers in this assay, from the lowest: compounds 4 and 1 (each within the scatter of the next); then compound 2; then compound 3.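

In this assay the step with isopropyl in place of propyl on an amine nitrogen reads a number 0.12 log units lower from compound 1 to compound 4 (within the scatter) and so does not separate the branched group from the straight one at this position. Isopropyl in place of pentyl reads a number 1.15 log units lower from compound 2 to compound 4 (beyond the scatter) and so places compound 4 with the shorter chain of compound 1 rather than with compound 2. Nothing measured here accounts for this result.

On these data alone, whether branching stays equally indistinct in a larger group remains open, such as a branched pentyl on the same nitrogen. A tert-butyl or cyclopropyl group there is also unresolved.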